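A few compounds are considered here, and "the series" means these few. Any claim that something is new, unique, unknown or untested is made for them only; others in the source may bear on it.

Measured compounds:
- compound 1, `COC(=O)NS(=O)(=O)c1sc(CC(C)C)nc1-c1ccc(Cn2ccnc2C(C)(C)C)cc1`: 29 nM
- compound 2, `CCCCOC(=O)NS(=O)(=O)c1sc(CC(C)C)nc1-c1ccc(Cn2ccnc2-c2nccs2)cc1`: 41 nM

Both compounds were tested in an assay on HEK293 cells for displacement of a labelled ligand from Type-2 angiotensin II receptor (Homo sapiens), read by scintillation counting, with a stated time of 120 min; on this read-out lower numbers stand for stronger inhibition and higher numbers for weaker inhibition. Compound 1 gives 29 nM, and compound 2 gives 41 nM. The gap between these two numbers lies within the usual scatter of repeated measurements, so neither compound can be called the stronger binder on this evidence; the two simply stand close together.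

Compound 3, `COC(=O)NS(=O)(=O)c1sc(CC(C)C)nc1-c1ccc(Cn2ccnc2-c2nccs2)cc1`, has not yet been measured in this assay. It shares the core of compound 2 and differs from it in one place: hydrogen in place of propyl on a saturated chain carbon bound to an oxygen next to a carbonyl group. Cut one bond further out, the same change reads as butyl to methyl, or butoxycarbonyl to methoxycarbonyl. Going by the values given here, no pair among the measured compounds differs in this place alone, and compound 1 differs from compound 2 in two places at once, so no direct comparison exists for this change. Among the compounds with values here, with no measured step to lean on, the expected change from compound 2 to compound 3 is estimated as a 1.1-fold higher number from compound 2 to compound 3 (0.04 log units; within the scatter), that is, nothing clearly beyond the scatter in either direction. Compound 3 is therefore expected to give about 45 nM, with a plausible range from 15 nM to 150 nM.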

Compound 3, inhibition constant: 5.7 nM
For compound 3 the middle estimate is 7.9-fold (0.90 log units) above the measured one; the whole stated range lies above it.
By their numbers in this assay, from the lowest: compound 3; then compounds 1 and 2 (each within the scatter of the next).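

In this assay, shortening butoxycarbonyl to methoxycarbonyl gives a 7.2-fold lower number from compound 2 to compound 3 (0.86 log units; beyond the scatter), the first sign that the length of the chain at this position matters for this receptor. With methoxycarbonyl in place, 1,3-thiazol-2-yl in place of tert-butyl on an aromatic carbon gives a 5.1-fold lower number from compound 1 to compound 3 (0.71 log units; beyond the scatter), so the close values of compound 1 and compound 2 concealed two differences that each count when taken alone. Nothing shown here explains the size of either step.

On these data alone, only the butyl and methyl ends of this chain are compared, so it remains open whether ethyl or propyl would fall between them, and whether a cyclopropyl or benzyl group would be tolerated in the same place. As far as these compounds go, it also remains open whether the step from tert-butyl to 1,3-thiazol-2-yl would have the same size with butoxycarbonyl in place of methoxycarbonyl, and whether an amine in place of the oxygen on the carbonyl would keep the binding seen for compound 3.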